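The source may hold more compounds than are shown below. What is called first, only, known or untested is meant among the compounds shown, and "the series" means these compounds.

Three close relatives of compound 2 `CC(C)(C)OC(=O)/C=C1/C(=O)Nc2ccccc21` have been tested in a functional assay on SK-BR-3 cells (Homo sapiens) for inhibition, read by CCK-8 assay, with a stated time of 72 h, tested at 20 uM (a lower number here means less inhibition of growth, a higher number more inhibition of growth at the concentration tested), and compound 2 gives 87.3%. Compound 1 `CCOC(=O)/C=C1/C(=O)Nc2ccccc21`, which carries an ethyl rather than a tert-butyl group on the ester oxygen, gives 85.5% in this assay; compound 3 `CC(C)(C)OC(=O)/C=C1/C(=O)N(Cc2ccccc2)c2ccccc21`, with a benzyl group on the ring nitrogen, gives 88%. The three numbers sit within the usual scatter of one another: the step is a number 1.8 percentage points higher from compound 1 to compound 2 (within the scatter) and then a number 0.7 percentage points higher from compound 2 to compound 3 (within the scatter).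

Compound 4 `CC(C)c1ccc2c(c1)/C(=C\C(=O)OC(C)(C)C)C(=O)N2` has not yet been measured. It differs from compound 2 only in isopropyl in place of hydrogen on an aromatic carbon. Neither measured step touches that ring: one changes the ester group, the other the ring nitrogen, and both stayed within the scatter. For the measured compounds named here, no measured pair therefore speaks directly to the new change. What the shared core has shown so far is a growth inhibition that barely moves when peripheral groups are swapped, so the expectation is that the isopropyl group will likewise bring no step beyond the scatter, which is what a number 0.3 percentage points lower from compound 2 to compound 4 (within the scatter) expresses. In this assay compound 4 is expected to give about 87%, with a plausible range from 75% to 95%.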

Compound 4, percent growth inhibition at one concentration: 88.5%
The estimate for compound 4 lay 1.5 percentage points below the measured number; low and high end bracket the measured number.
By their numbers in this assay, from the lowest: compounds 1, 2, 3 and 4 (each within the scatter of the next).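

In this assay, the isopropyl group on an aromatic carbon of the six-membered aromatic ring gives a number 1.2 percentage points higher from compound 2 to compound 4 (within the scatter). For the compounds shown here, this is the first look at that ring, which neither earlier step touched, and it shows that this carbon can carry a branched group of 3 heavy atoms instead of a hydrogen with no step beyond the scatter, so changes at the ester group, the ring nitrogen and now this aromatic carbon have each stayed within the scatter. Nothing available here explains why this change leaves the growth inhibition within the scatter.

On these data alone, it remains open whether this carbon would tolerate a group of a different kind just as well, such as an amine, a carboxylic acid or a longer chain, and whether isopropyl would behave the same way on another carbon of that ring or alongside the benzyl group on the ring nitrogen. Because all of these readings come from a single concentration, they also leave open whether the compounds would separate at lower concentrations.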